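The source may report more compounds than this note shows. Statements on the series, on what has been measured and on what is new or still open speak of the compounds shown alone.

In a functional assay on HL-60 cells (Homo sapiens) for inhibition, read by CCK-8 assay, with a stated time of 48 h (on this read-out lower numbers stand for stronger inhibition and higher numbers for weaker inhibition), compound 1 `Nc1ccc(Oc2ccccc2-c2ccc(S(=O)(=O)NCCNC(=O)Nc3ccc(Cl)cc3)s2)cc1` gives > 50000 nM, which is a limit of the assay and not a number. Compound 1 is thus the one entry at the limit of > 50000 nM in this assay, at which 1 of the 3 values shown sits. Two relatives do give numbers: compound 2 `Cc1ccc(-c2ccsc2S(=O)(=O)NCCNC(=S)Nc2ccc([N+](=O)[O-])cc2)c(Oc2ccc(O)c(O)c2)c1` reads 2900 nM and compound 3 `O=C(NCCNS(=O)(=O)c1ccc(-c2ccccc2Oc2ccc([N+](=O)[O-])c([N+](=O)[O-])c2)s1)Nc1ccc(Cl)cc1` reads 8100 nM.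

Compound 4 `Cc1cc(C)cc(NC(=O)NCCNS(=O)(=O)c2ccc(-c3ccccc3Oc3ccc(N)cc3)s2)c1` changes one group of compound 1: 3,5-dimethylphenyl in place of 4-chlorophenyl on an amide-type nitrogen. Put simply, 3,5-dimethylphenyl takes the place of 4-chlorophenyl on an amide-type nitrogen.

Going by the values given here, the only measured step between these relatives, an at least 6.1-fold lower number from compound 1 to compound 3 (0.79 log units; beyond the scatter), is a sizeable one, but it lies at a different place, on an oxygen on an aromatic ring. It leaves the 4-chlorophenyl untouched, so it says nothing about the size or direction of the present change. Compound 4 also keeps the 4-aminophenyl on oxygen, the group that compound 3 gave up in that step.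

The best guide is therefore compound 1 itself, with its limit of > 50000 nM, and no step beyond the scatter is expected in this assay, in either direction. The expected step is an at least 1.1-fold lower number from compound 1 to compound 4 (0.04 log units; that floor lies within the scatter). The estimate for compound 4 is 45000 nM, with an expected range from 12000 nM to 90000 nM.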

Compound 4, half-maximal inhibitory concentration: > 50000 nM
Compound 4 gave a limit, no number; the forecaster's own chance of this, stated with the estimate: 55%; at least 1.1-fold (0.04 log units) between middle value and limit.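

In this assay compound 4 gives > 50000 nM, which is a limit of the assay and not a number. Compound 1 gives > 50000 nM, also a limit. With two limits, no step can be read between compound 1 and compound 4. The compounds shown leave open whether swapping 4-chlorophenyl for 3,5-dimethylphenyl changes inhibition at all.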